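Cyclopentyl added to the ketone chain of compound 2

A few compounds are considered here, and "the series" means these few. Any claim that something is new, unique, unknown or untested is made for them only; others in the source may bear on it.

In an assay on HEK293 cells for positive allosteric modulation of metabotropic glutamate receptor 2 (Rattus norvegicus), read by thallium flux, with a stated time of 2.5 min (a higher number here means that more compound is needed for the effect, a lower number that less compound is needed), compound 2, whose structure is `CC(=O)c1ccc(OCCCCOc2ccc(C(=O)O)cc2C)c(C)c1O`, gives 50 nM. Among the two compounds measured, compound 2 stands at the lowest number; the other measured compound, compound 1 with structure `Cc1c(OCCCCOc2ccc(C(=O)O)cc2)ccc(C(=O)CC2CCCC2)c1O`, gives 824 nM in this assay, a gap well beyond the scatter. Compound 1 and compound 2 differ in more than one place, so only their two values can be compared here.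

Compound 3, with structure `Cc1cc(C(=O)O)ccc1OCCCCOc1ccc(C(=O)CC2CCCC2)c(O)c1C`, is not yet measured. It differs from compound 2 in one way: cyclopentyl in place of hydrogen on a saturated chain carbon bound to a carbonyl carbon. Compound 3 carries the same (cyclopentylmethyl)carbonyl group that compound 1 carries, while keeping the rest of compound 2 unchanged. The higher number of compound 1 at 824 nM in this assay is the only hint of the direction this change might take, and it points toward a higher number for compound 3. Compound 3 is therefore expected to give about 300 nM in this assay, within a range of 80 nM to 1200 nM, which would be a step of a 6.0-fold higher number from compound 2 to compound 3 (0.78 log units; beyond the scatter), expected to lie beyond the scatter.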

Compound 3, half-maximal effective concentration: 608 nM
For compound 3 the middle estimate is 2.0-fold (0.31 log units) below the measured one; measured number inside the range.
By their numbers in this assay, from the lowest: compound 2; then compounds 3 and 1 (each within the scatter of the next).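

In this assay, within the data shown here, cyclopentyl in place of hydrogen on a saturated chain carbon bound to a carbonyl carbon gives a large step (a 12-fold higher number from compound 2 to compound 3 (1.08 log units; beyond the scatter)), which is the first reading of this change alone, since compound 1 and compound 2 differ in more than one place. Methyl in place of hydrogen on an aromatic carbon gives a step that stays within the scatter (a 1.4-fold lower number from compound 1 to compound 3 (0.13 log units; within the scatter)), so with the (cyclopentylmethyl)carbonyl group present, this methyl has no readable effect on the number in this assay. The study offers no measurement that would explain either step.

The compounds shown leave open whether the large step belongs to the cyclopentyl ring itself or would also appear with an open chain such as ethyl or isopropyl, or with another ring such as cyclopropyl or phenyl, on the same saturated chain carbon. They also leave open whether the methyl on the aromatic carbon would remain without a readable effect when the acetyl group of compound 2 is present in place of the (cyclopentylmethyl)carbonyl group.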